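This account rests on a few compounds, and the source may have more. Where it says the series, first, only, none or still open, it means among the compounds named here.

Measured so far in a functional assay on LOX IMVI cells (Homo sapiens) for cytotoxicity, read by MTT assay, with a stated time of 24 h; a higher number here means a weaker inhibitor, a lower number a stronger inhibitor:
compound 1 `COc1ccc(S(=O)(=O)NCCCNc2nccc(-c3[nH]c(-c4ccccc4)nc3-c3ccc(Cl)c(OC)c3)n2)cc1`: 1800 nM
compound 2 `O=S(=O)(NCCCNc1nccc(-c2[nH]c(-c3ccccc3)nc2-c2ccc(F)c(O)c2)n1)c1ccc(C(F)(F)F)cc1`: 2450 nM
compound 3 `O=S(=O)(NCCCNc1nccc(-c2[nH]c(-c3ccccc3)nc2-c2ccc(F)c(O)c2)n1)c1cccc(F)c1`: 7890 nM

Of these three, compound 3 gives the highest number, and both other values lie beyond the scatter from it. Compound 4 `COc1ccc(S(=O)(=O)NCCCNc2nccc(-c3[nH]c(-c4ccccc4)nc3-c3ccc(F)c(O)c3)n2)cc1` is still unmeasured. It keeps all of compound 3 except the group on the sulfonyl sulfur, where 4-methoxyphenyl stands in place of 3-fluorophenyl (4-methoxyphenyl in place of 3-fluorophenyl on a sulfonyl sulfur).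

Among the compounds with values here, one measured step bears directly on this place: 3-fluorophenyl in place of 4-(trifluoromethyl)phenyl gave a 3.2-fold higher number from compound 2 to compound 3 (0.51 log units; beyond the scatter), a modest step. Compound 1 already carries 4-methoxyphenyl on the sulfonyl sulfur and gives 1800 nM. It differs from the new compound elsewhere in the structure, however, so it is only a loose guide. Within the data shown here, no pair of compounds compares the two groups directly on one core.

A modest move to a lower number is therefore expected in this assay, no larger than the measured step. The expected change is a 2.3-fold lower number from compound 3 to compound 4 (0.35 log units; beyond the scatter). For compound 4 the estimate is 3500 nM, with an expected range of 1500 nM to 8000 nM.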

Compound 4, half-maximal inhibitory concentration: 13900 nM
Compound 4: middle estimate off by 4.0-fold (0.60 log units), on the low side; the whole stated range lies below it.
By their numbers in this assay, from the lowest: compounds 1 and 2 (each within the scatter of the next); then compounds 3 and 4 (each within the scatter of the next).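

On the core shared by compounds 2, 3 and 4, this assay does not separate 4-methoxyphenyl from 3-fluorophenyl on the sulfonyl sulfur, as shown by a 1.8-fold higher number from compound 3 to compound 4 (0.25 log units; within the scatter) and the printed scatter. The 4-(trifluoromethyl)phenyl group of compound 2 stands apart from both, and the new comparison gives a 5.7-fold higher number from compound 2 to compound 4 (0.75 log units; beyond the scatter) with methoxy in place of trifluoromethyl on an aromatic carbon. With 4-methoxyphenyl now held constant on the sulfonyl sulfur, the other aromatic group also matters, since 4-fluoro-3-hydroxyphenyl in place of 4-chloro-3-methoxyphenyl gives a 7.7-fold higher number from compound 1 to compound 4 (0.89 log units; beyond the scatter) and so compound 1 proved a poor stand-in for this core. Nothing measured here explains either difference.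

As far as these compounds go, whether 4-(trifluoromethyl)phenyl would stand apart in the same way on the core of compound 1 remains open. From the compounds shown here alone, it is also open how an amine or a carboxylic acid on the aromatic ring of the sulfonyl group, or a plain methyl group on the sulfonyl sulfur in place of that ring, would read in this assay on either core.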